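The compounds below may be only part of what the source reports. "The series", "measured", "known", "first", "only" and "open" are said of these compounds alone.

Series notes. Compound 2 `CCCn1c(=O)[nH]c2nc(-c3ccc(S(=O)(=O)N4CCN(c5cccc(F)c5)CC4)cc3)[nH]c2c1=O` stands highest of the two numbers shown in an assay on CHO cells for displacement of a labelled ligand from adenosine receptor A3 (Homo sapiens), read by scintillation counting, with a stated time of 45 min, tested at 1 uM, in the presence of a further agent that is not named here (on this read-out lower numbers stand for less inhibition and higher numbers for more inhibition at the one concentration tested (going by the name of the read-out)), where compound 2 gives 44%; its nearest neighbour compound 1 `CCCn1c(=O)[nH]c2nc(-c3ccc(S(=O)(=O)N4CCN(Cc5cccc(Br)c5)CC4)cc3)[nH]c2c1=O` gives 23%, the step being a number 21 percentage points higher from compound 1 to compound 2 (beyond the scatter). Compound 3 `CCCn1c(=O)[nH]c2nc(-c3ccc(S(=O)(=O)N4CCN(c5ccccc5)CC4)cc3)[nH]c2c1=O` differs from compound 2 by hydrogen in place of fluoro on an aromatic carbon. Among the measured compounds shown here, no measured step bears directly on a fluoro-to-hydrogen change; the one step to hand exchanges a 3-bromobenzyl for a 3-fluorophenyl and is modest. A step within the scatter, a number 4 percentage points lower from compound 2 to compound 3 (within the scatter), is therefore expected. Compound 3 is estimated at 40%, range 25% to 55%.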

Compound 3, a percentage reported as inhibition, at one concentration (the size of the read-out at that concentration, not a potency): 27%
For compound 3 the middle estimate is 13 percentage points above the measured one, and the stated range covers the measured number.
By their numbers in this assay, from the lowest: compounds 1 and 3 (each within the scatter of the next); then compound 2.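

In this assay, the change from 3-fluorophenyl to phenyl gives a number 17 percentage points lower from compound 2 to compound 3 (beyond the scatter), so the higher number of compound 2 depends on the fluoro on this aromatic carbon, meta to a large group. With a number 4 percentage points higher from compound 1 to compound 3 (within the scatter), phenyl and 3-bromobenzyl on the ring amine nitrogen are not separated, which places the earlier gain with the fluoro rather than with the change from benzyl to phenyl alone. Nothing at hand explains the effect of the fluoro. Going by these compounds, whether chloro, methoxy or an amine on this same aromatic carbon would match compound 2 remains open.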